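Cyano in Place of an Aryl Ketone on a Shared Core

The compounds below may be only part of what the source reports. "The series", "measured", "known", "first", "only" and "open" are said of these compounds alone.

In a functional assay on HepG2 cells (Homo sapiens) for cytotoxicity, read by sulforhodamine B assay (on this read-out higher numbers stand for weaker inhibition and lower numbers for stronger inhibition), compound 1 `O=C(c1cccnc1)c1cc2c(-c3cccnc3)nn(-c3ccccc3)c2[nH]c1=O` gives 11 ug/mL, and compound 2 `O=C(c1ccc(Cl)cc1)c1cc2c(-c3cccnc3)nn(-c3ccccc3)c2[nH]c1=O` gives 9 ug/mL. Going by the values given here, the single measured step, a 1.2-fold lower number from compound 1 to compound 2 (0.09 log units; within the scatter), exchanges one aryl group on the carbonyl for another. Among the compounds with values here, compound 2 stands at the lowest of the two numbers measured so far, with compound 1 sitting within the scatter of it. Compound 3 `N#Cc1cc2c(-c3cccnc3)nn(-c3ccccc3)c2[nH]c1=O` carries the change (cyano in place of (4-chlorophenyl)carbonyl on an aromatic carbon). Within the data shown here, no measured step removes this carbonyl group altogether; the step from compound 1 to compound 2 only alters the aryl ring attached to it and stays within the scatter. There is thus no direct guide to the size or direction of the step to compound 3, and the account expects a number not far from that of compound 2. Compound 3 is expected to give 15 ug/mL, between 5 ug/mL and 45 ug/mL, which would mean a step of a 1.7-fold higher number from compound 2 to compound 3 (0.22 log units; within the scatter).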

Compound 3, half-maximal inhibitory concentration: 3.3 ug/mL
For compound 3 the middle estimate is 4.5-fold (0.66 log units) above the measured one, outside the stated range (below it).
By their numbers in this assay, from the lowest: compound 3; then compounds 2 and 1 (each within the scatter of the next).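

In this assay, cyano in place of the aryl ketone gives a 2.7-fold lower number from compound 2 to compound 3 (0.44 log units; beyond the scatter) and a 3.3-fold lower number from compound 1 to compound 3 (0.52 log units; beyond the scatter), so this aromatic carbon shows a response beyond the scatter, which the exchange of one aryl group for another on the carbonyl had not shown. The aryl ketone is therefore not required for activity on this read-out, and compound 3, with only the small cyano group at this place, has the lowest number of the three. Nothing given here accounts for this shift.

Cyano replaces the carbonyl and its aryl ring in one step, so these compounds cannot separate the loss of the ketone from the arrival of the nitrile. On these data alone, it also remains open how a carboxylic acid, a primary amide or a methyl group on this aromatic carbon would compare with cyano.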